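The source may report more compounds than this note shows. Statements on the series, on what has been measured and on what is new or still open speak of the compounds shown alone.

Measured so far:
compound 1 `O=C(NCCCCc1ccccc1)c1cccc(C2SCC(=O)N2c2cccc(F)c2)c1` — 10000 nM
compound 2 `CC(F)(F)c1cccc(N2C(=O)CSC2c2cccc(C(=O)NCCCCc3ccccc3)c2)c1` — 10000 nM

In a physicochemical assay for solubility, read by turbidimetry, measured as kinetic solubility, at pH 6.8 (on this read-out higher numbers stand for higher solubility and lower numbers for lower solubility), compound 2 gives 10000 nM, level with compound 1 at the digits shown, and the one measured step, no change at the digits printed from compound 1 to compound 2 (within the scatter), stayed within the scatter. Compound 3 `O=C(NCCCCc1ccccc1)c1cccc(C2SCC(=O)N2c2ccc(C3CC3)cc2)c1` differs from compound 2 by a group of 9 heavy atoms (9 carbon; one three-membered non-aromatic ring of carbon only, one six-membered aromatic ring of carbon only) in place of a group of 10 heavy atoms (8 carbon, 2 fluorine; one six-membered aromatic ring of carbon only), on an amide-type nitrogen in a ring. That earlier step also altered the group on the amide-type nitrogen in a ring and moved nothing beyond the scatter, so no step beyond the scatter is expected here either: no change at the digits printed from compound 2 to compound 3 (within the scatter). Compound 3 is therefore estimated at 10000 nM, with a range from 4000 nM to 20000 nM.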

Compound 3, solubility: 2000 nM
Compound 3: middle estimate off by 5.0-fold (0.70 log units), on the high side; measured number outside the range, below it.
By their numbers in this assay, from the lowest: compound 3; then compounds 1 and 2 (each within the scatter of the next).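

In this assay the group on the amide-type nitrogen in a ring now proves able to move the number: 4-cyclopropylphenyl in place of 3-fluorophenyl gives a 5.0-fold lower number from compound 1 to compound 3 (0.70 log units; beyond the scatter) and the other step into this group gives a 5.0-fold lower number from compound 2 to compound 3 (0.70 log units; beyond the scatter) beyond the scatter. The earlier change at this same place had stayed within the scatter, so this position does not treat all groups alike. Nothing here explains the drop.

Going by these compounds, it remains open whether the cyclopropyl itself or its location on the phenyl ring goes with the lower number. Also open, on these data alone, is what an amine or a carboxylic acid on that phenyl ring would give.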